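Trimethoxyphenyl in Place of Dichlorophenyl: Expected Cytotoxicity

The source may report more compounds than this note shows. Statements on the series, on what has been measured and on what is new or still open speak of the compounds shown alone.

The measured compounds:
compound 1, `Cc1ccc(S(=O)(=O)/N=C(/CCNC2=CC(=O)c3ccccc3C2=O)Nc2ccc(F)c(F)c2)cc1`, 16700 nM in a functional assay on A549 cells (Homo sapiens) for cytotoxicity, read by MTT assay, with a stated time of 48 h; a lower number here means a stronger inhibitor, a higher number a weaker inhibitor
compound 2, `COc1ccc(N/C(CCNC2=CC(=O)c3ccccc3C2=O)=N\S(=O)(=O)c2ccc(C)cc2)c(OC)c1`, 126000 nM
compound 3, `Cc1ccc(S(=O)(=O)/N=C(/CCNC2=CC(=O)c3ccccc3C2=O)Nc2ccc(Cl)cc2Cl)cc1`, 32900 nM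

Compound 3 stands second highest of the three numbers. Its nearest neighbour is compound 1, the step of a 2.0-fold higher number from compound 1 to compound 3 (0.29 log units; within the scatter) lying within the scatter; its furthest is compound 2, through the step of a 3.8-fold lower number from compound 2 to compound 3 (0.58 log units; beyond the scatter).

Compound 4, `COc1cc(N/C(CCNC2=CC(=O)c3ccccc3C2=O)=N\S(=O)(=O)c2ccc(C)cc2)cc(OC)c1OC`, differs from compound 3 in one place: 3,4,5-trimethoxyphenyl in place of 2,4-dichlorophenyl on an amine nitrogen. Among the measured compounds shown here, two measured steps bear on this. The step of a 7.5-fold higher number from compound 1 to compound 2 (0.88 log units; beyond the scatter) and the step of a 3.8-fold lower number from compound 2 to compound 3 (0.58 log units; beyond the scatter) both show methoxy-bearing phenyl giving the higher number against halogenated phenyl. Compound 4 is therefore expected to show a modest rise in this assay, a 3.0-fold higher number from compound 3 to compound 4 (0.48 log units; beyond the scatter). For compound 4 the estimate is 100000 nM, with a range from 40000 nM to 250000 nM.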

Compound 4, half-maximal inhibitory concentration: 7940 nM
Beside the measured number, compound 4's estimate is 13-fold (1.10 log units) above it, and the stated range ends above it.
By their numbers in this assay, from the lowest: compound 4; then compounds 1 and 3 (each within the scatter of the next); then compound 2.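

In this assay the 3,4,5-trimethoxyphenyl group on the amine nitrogen gives a 4.1-fold lower number from compound 3 to compound 4 (0.62 log units; beyond the scatter) and a 2.1-fold lower number from compound 1 to compound 4 (0.32 log units; beyond the scatter) and a 16-fold lower number from compound 2 to compound 4 (1.20 log units; beyond the scatter) and so holds the lowest number of the four. Methoxy-bearing phenyl therefore does not simply go with the higher number: compound 2 fits that reading, compound 4 goes against it, and these two stand at opposite ends of the series. Nothing given here explains this reversal. The compounds shown leave open how a single methoxy group on this phenyl would read, and whether an amine or a carboxylic acid there would keep the low number.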